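Methyl on the aryl ring of a dienone

This account rests on a few compounds, and the source may have more. Where it says the series, first, only, none or still open, it means among the compounds named here.

Compound 1 `CC1=C(/C=C/C(=O)/C=C/c2ccccc2)C(C)(C)CCC1O` gives 8000 nM
Compound 2 `CC1=C(/C=C/C(=O)/C=C/c2ccc(C(F)(F)F)cc2)C(C)(C)CCC1O` gives 3200 nM
Compound 3 `CC1=C(/C=C/C(=O)/C=C/c2cc(F)cc(C(F)(F)F)c2)C(C)(C)CCC1O` gives 2400 nM

In a functional assay on CWR22R cells (Homo sapiens) for cytotoxicity, read by MTT assay, with a stated time of 72 h (on this read-out lower numbers stand for stronger inhibition and higher numbers for weaker inhibition), compound 1 stands highest of the three numbers; compound 2 sits nearer and compound 3 furthest below it. Going by the values given here, the only step that differs in one place, a 2.5-fold lower number from compound 1 to compound 2 (0.40 log units; beyond the scatter), came from a trifluoromethyl in place of hydrogen on an aromatic carbon. Compound 4 `CC1=C(/C=C/C(=O)/C=C/c2cccc(C)c2)C(C)(C)CCC1O` instead carries methyl in place of hydrogen on an aromatic carbon, a change of a different kind, so that step bears on it only loosely. Methyl in place of hydrogen is expected to move the number little, if at all beyond the scatter, perhaps slightly downward. For compound 4 the estimate is 6000 nM, within 2500 nM to 15000 nM, a step of a 1.3-fold lower number from compound 1 to compound 4 (0.12 log units; within the scatter).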

Compound 4, half-maximal inhibitory concentration: 4400 nM
Beside the measured number, compound 4's estimate is 1.4-fold (0.13 log units) above it; measured number inside the range.
By their numbers in this assay, from the lowest: compounds 3, 2, 4 and 1 (each within the scatter of the next, the first and the last beyond it).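

In this assay, methyl on an aromatic carbon, meta to a large group, gives a 1.8-fold lower number from compound 1 to compound 4 (0.26 log units; within the scatter), so at this position methyl cannot be told apart from hydrogen. The earlier step, with trifluoromethyl in place of hydrogen, lay beyond the scatter, so not every small group on this ring shifts the number by a readable amount, although the two groups sit at different places. No measurement on hand gives a reason for this result. On these data alone, whether an amine or a carboxylic acid at this same position would give a step beyond the scatter stays open. So does whether methyl elsewhere on the ring would read like hydrogen.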